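A few compounds are considered here, and "the series" means these few. Any claim that something is new, unique, unknown or untested is made for them only; others in the source may bear on it.

In a functional assay on HT-29 cells (Homo sapiens) for cytotoxicity, read by MTT assay, with a stated time of 48 h (on this read-out higher numbers stand for weaker inhibition and lower numbers for stronger inhibition), compound 3 `COc1ccc(/C=N/n2c(SCc3ccccc3Cl)nnc2-c2cc(OC)c(OC)c(OC)c2)c(OC)c1` gives only a limit of the assay, > 200000 nM. Compound 1 `COc1cc(-c2nnc(SCc3ccccc3Cl)n2/N=C/c2ccccc2)cc(OC)c1OC` likewise sits at a limit, > 200000 nM. Compound 2 `COc1ccc(/C=N/n2c(SCc3ccc(F)cc3)nnc2-c2cc(OC)c(OC)c(OC)c2)c(OC)c1` gives a number, 126000 nM. The step that the two limits leave unreadable from compound 1 to compound 3 is unreadable, and the step of an at least 1.5-fold higher number from compound 2 to compound 3 (0.20 log units; that floor lies within the scatter) has only a floor that lies within the scatter, both shaped by the limit of > 200000 nM in this assay, at which 2 of the 3 values shown sit. Compound 4 `CCOC(=O)CSc1nnc(-c2cc(OC)c(OC)c(OC)c2)n1/N=C/c1ccc(OC)cc1OC` differs from compound 3 by ethoxycarbonyl in place of 2-chlorophenyl on a saturated chain carbon bound to a sulfur. For the measured compounds named here, no measured step exchanges the sulfur-bound benzyl group for a non-aromatic chain, so the measured steps give neither a size nor a direction for this change. One therefore expects the step of a number no higher from compound 3 to compound 4 (the limit leaves the size open) to stay within the scatter. For compound 4 the estimate is 200000 nM, between 80000 nM and 500000 nM, most likely again reported only as a limit.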

Compound 4, half-maximal inhibitory concentration: > 200000 nM
Compound 4 was reported as a limit; the forecaster's own chance of this, stated with the estimate: 60%; the middle value lies on the limit itself.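

In this assay compound 4 also gives only a limit, so an ethoxycarbonyl group with no ring, on a saturated chain carbon bound to a sulfur, yields no readable number, just as the 2-chlorophenyl of compound 3 did. For the compounds shown here, the steps between two limits cannot be read, and the one remaining step, an at least 1.5-fold higher number from compound 2 to compound 4 (0.20 log units; that floor lies within the scatter), sets no difference beyond the scatter. Little can be resolved at this place: the limit of > 200000 nM in this assay, at which 3 of the 4 values shown sit.

From the compounds shown here alone, whether a carboxylic acid or an amine at this place would give a number inside the assay's range stays open. Going by these compounds, the true size of the change from 2-chlorophenyl to ethoxycarbonyl also stays open.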